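Swapping Chloro for Hydroxy on a Hydrazone Arm

The source may report more compounds than this note shows. Statements on the series, on what has been measured and on what is new or still open speak of the compounds shown alone.

Measured so far:
compound 1 `O=C(N/N=C/c1ccc(Cl)cc1)c1cnccn1` — > 30 ug/mL
compound 2 `O=C(N/N=C/c1ccccc1O)c1cnccn1` — 11.4 ug/mL
compound 3 `O=C(N/N=C/c1cccc(O)c1)c1cnccn1` — > 30 ug/mL

All three share one core and differ only in the group carried on the outer benzene ring. In an ADME assay on Vero cells (Chlorocebus sabaeus) for cytotoxicity, with a stated time of 72 h (a lower number here means that less compound is tolerated, a higher number that more compound is tolerated), compound 1 gives > 30 ug/mL, which is a limit of the assay and not a measured number. For compound 3 the reading > 30 ug/mL is likewise a limit. For the measured compounds named here, compound 2 is the one with a real number, 11.4 ug/mL.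

Compound 4 `O=C(N/N=C/c1ccc(O)cc1)c1cnccn1` is reached from compound 1 by a single exchange: hydroxy in place of chloro on an aromatic carbon. Going by the values given here, no step between two measured compounds is available to say how this exchange usually moves the cytotoxicity value, so the expectation rests on where the known values sit, that is on (the limit of > 30 ug/mL in this assay, at which 2 of the 3 values shown sit).

For compound 4 the step that the limit leaves unreadable from compound 1 to compound 4 is expected to be none beyond the scatter. The expected value for compound 4 is 35 ug/mL, within a range of 15 ug/mL to 80 ug/mL, and most likely the assay will again report only a limit.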

Compound 4, half-maximal cytotoxic concentration: > 30 ug/mL
Compound 4 was reported as a limit (the forecaster's own chance of this, stated with the estimate: 65%); the middle value is on the limit's open side.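

Compound 1 and compound 4 are both reported only as limits in this assay, so no step can be read for hydroxy in place of chloro: the limit of > 30 ug/mL in this assay, at which 3 of the 4 values shown sit.

The compounds shown leave open whether this exchange changes the cytotoxicity value at all, since the true values of compound 1 and compound 4 remain unknown.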